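The compounds below may be only part of what the source reports. "The series", "measured", "known", "first", "only" and "open" are said of these compounds alone.

Series notes. Compound 1, `C[C@H](NC(=O)CN(c1nc(Cl)nc2[nH]cnc12)C1CC1)C(=O)OCc1ccccc1`, is the reference point here. In a functional assay on the whole organism (Tail, strain ICR) with Mus musculus as the target, in the tail flick test, with a stated time of 120 min, at a dose of 25 umol/kg by the oral route (a lower number here means a weaker effect, a higher number a stronger effect of the compound at the dose given), compound 1 gives 36.1%, the higher of the two numbers available, though the gap to its nearest neighbour lies within the scatter, so no order between them is claimed. That neighbour, compound 2, `O=C(CN(c1ncnc2c1ncn2C1CCCCO1)C1CC1)N[C@@H](CO)C(=O)OCc1ccccc1`, differs at several places at once; in this assay compound 2 gives 29.2%, and the pair shows only that both sit at a moderate level of activity.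

Compound 3, `CC[C@H](C)[C@H](NC(=O)CN(c1nc(Cl)nc2[nH]cnc12)C1CC1)C(=O)OCc1ccccc1`, follows from compound 1 by one change: sec-butyl in place of methyl on a saturated chain carbon bound to an amide-type nitrogen and a carbonyl carbon. For the measured compounds named here, no single-place step between measured compounds is available to calibrate this change, so no direction is supported by data. The step from compound 1 to compound 3 is expected to be small, likely within the scatter, as a number 1.1 percentage points lower from compound 1 to compound 3 (within the scatter). Compound 3 is accordingly estimated at 35% in this assay, within a range of 15% to 55%.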

Compound 3, a percentage reported as activity, at one dose (the size of the read-out at that dose, not a potency): 22%
Beside the measured number, compound 3's estimate is 13 percentage points above it, and the stated range covers the measured number.
By their numbers in this assay, from the lowest: compounds 3, 2 and 1 (each within the scatter of the next, the first and the last beyond it).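

For the compounds shown here, the step of a number 14.1 percentage points lower from compound 1 to compound 3 (beyond the scatter) is the first single-place comparison, and it shows that in this assay the read-out responds to the group on the saturated chain carbon bound to an amide-type nitrogen and a carbonyl carbon. Sec-butyl in place of methyl adds carbon but no hydrogen-bond donors or acceptors and no net charge, and that change alone gives a step beyond the scatter, towards a weaker effect at the dose given. Nothing measured here bears on why the read-out falls.

On these data alone, with only methyl and sec-butyl compared on this core, it remains open whether the fall follows chain length or branching, which an ethyl, isopropyl or straight butyl group would help separate. As far as these compounds go, the effect of an aminomethyl group at this position also remains open.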